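This account rests on a few compounds, and the source may have more. Where it says the series, first, only, none or still open, it means among the compounds named here.

Three compounds from this series have been run in a functional assay on HCC827 cells (Homo sapiens) for inhibition, read by MTT assay, with a stated time of 48 h, tested at 10 uM (a lower number here means less inhibition, a higher number more inhibition at the concentration tested (going by the name of the read-out)), and a fourth awaits its number. Compound 1, `COc1cc(NC(=O)Nc2cc(Nc3ccc(OC)c(C)c3)ncn2)cc(OC)c1`, gives 48.3% in this assay, the lowest of the three numbers shown. Compound 3, `COc1cc(Nc2cc(NC(=O)Nc3c(Cl)cccc3Cl)ncn2)cc(C(F)(F)F)c1`, gives 57.7%, a number that sits within the usual scatter of compound 1. Compound 2, `COc1ccc(C(F)(F)F)cc1Nc1cc(NC(=O)Nc2c(Cl)cccc2Cl)ncn1`, gives 68.7%, which stands clearly higher than compound 1, beyond the scatter. For the measured compounds named here, compounds 2 and 3 differ from compound 1 in more than one place, so no single step between measured compounds can be read from them.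

Compound 4, `COc1cc(NC(=O)Nc2cc(Nc3ccc(F)c(Cl)c3)ncn2)cc(OC)c1`, is built from compound 1 by one change: 3-chloro-4-fluorophenyl in place of 4-methoxy-3-methylphenyl on a nitrogen on an aromatic ring. The shared core and the urea side of the molecule stay as they are in compound 1. Going by the values given here, with no measured step to lean on, the expectation is for a small rise in this assay from compound 1 to compound 4, of a size that may not exceed the scatter: compound 4 is estimated at 56%, between 38% and 74%, a step of a number 7.7 percentage points higher from compound 1 to compound 4 (within the scatter).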

Compound 4, a percentage reported as inhibition, at one concentration (the size of the read-out at that concentration, not a potency): 53.1%
For compound 4 the middle estimate is 2.9 percentage points above the measured one; low and high end bracket the measured number.
By their numbers in this assay, from the lowest: compounds 1, 4 and 3 (each within the scatter of the next); then compound 2.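

For the compounds shown here, putting 3-chloro-4-fluorophenyl in place of 4-methoxy-3-methylphenyl on a nitrogen on an aromatic ring gives the first single-change reading: in this assay it produces a number 4.8 percentage points higher from compound 1 to compound 4 (within the scatter). The two groups therefore cannot be told apart in this assay, and this position accepts a ring carrying two halogens in place of one carrying methoxy and methyl with no shift beyond the scatter. Nothing available here offers a reason for this result.

As far as these compounds go, what remains open is whether a quite different group on this nitrogen, such as a cyclohexyl ring or a phenyl ring carrying a carboxylic acid, would move the number beyond the scatter. From the compounds shown here alone, it also remains open whether this same exchange would read alike with a different group on the urea side of the molecule.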